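A methoxy-for-hydroxyl swap on a salicylanilide-type inhibitor

A few compounds are considered here, and "the series" means these few. Any claim that something is new, unique, unknown or untested is made for them only; others in the source may bear on it.

Compound 1 `O=C(Nc1ccc(Sc2nc3ccccc3s2)cc1)c1cc(Br)cc(Br)c1O` is tested in an assay for inhibition of HSP60/HSP10 (Homo sapiens), with a stated time of 60 min (on this read-out lower numbers stand for stronger inhibition and higher numbers for weaker inhibition), where compound 1 gives 4700 nM. Among the two measured numbers it stands highest; its nearest neighbour is compound 2 `O=C(Nc1ccc(Sc2nc3ccccc3s2)c(Cl)c1)c1cc(Br)cc(Br)c1O`, which in this assay gives 4200 nM. Among the measured compounds shown here, the only single-place step measured is a 1.1-fold lower number from compound 1 to compound 2 (0.05 log units; within the scatter), and it does not touch the amide side of the molecule. Compound 3 `COc1ccc(Br)cc1C(=O)Nc1cccc(Cl)c1` reaches only a limit of this assay, > 100000 nM, so for compound 3 no number is known. That limit is described as the limit of > 100000 nM in this assay, at which 1 of the 3 values shown sits.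

Compound 4 `COc1c(Br)cccc1C(=O)Nc1ccc(Sc2nc3ccccc3s2)cc1` arises from compound 1 by a group of 9 heavy atoms (7 carbon, 1 oxygen, 1 bromine; one six-membered aromatic ring of carbon only) in place of a group of 9 heavy atoms (6 carbon, 1 oxygen, 2 bromine; one six-membered aromatic ring of carbon only), on a carbonyl carbon. For the measured compounds named here, no measured step bears directly on this change, since the one step known sits elsewhere and stays within the scatter. Going by the values given here, the only compound lacking the 3,5-dibromo-2-hydroxyphenyl, compound 3, gives no number at all. Compound 4 is therefore expected to show weaker inhibition, a step of a 6.4-fold higher number from compound 1 to compound 4 (0.81 log units; beyond the scatter), with an estimated value of 30000 nM and a likely range from 8000 nM to 100000 nM.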

Compound 4, half-maximal inhibitory concentration: > 100000 nM
Compound 4: a limit, no number (the forecaster's own chance of this, stated with the estimate: 35%); middle value at least 3.3-fold (0.52 log units) away from the limit.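

With the core of compound 1 held constant, changing only the group on the carbonyl carbon gives an at least 21-fold higher number from compound 1 to compound 4 (1.32 log units; beyond the scatter) in this assay. Compound 3 differed from compound 1 in more than one place, so it could not show this; now the loss of inhibition can be tied to the 3,5-dibromo-2-hydroxyphenyl group alone, whereas the change elsewhere, a 1.1-fold lower number from compound 1 to compound 2 (0.05 log units; within the scatter), made no clear difference. For compound 4 the result is a limit, not a number, so the true size of the step stays unknown: the limit of > 100000 nM in this assay, at which 2 of the 4 values shown sit.

The entering group has no hydrogen-bond donor and one bromine fewer, and these two differences arrive together, so the compounds shown cannot separate them. As far as these compounds go, it also remains open whether another group in place of the hydroxyl, such as an amine, would keep any inhibition.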